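The source may report more compounds than this note shows. Statements on the series, on what has been measured and on what is new or still open speak of the compounds shown alone.

Working notes on the series

Three compounds of the series have been run in an ADME assay on MDCKII-LE cells (Canis lupus familiaris) for permeability, in the apical to basolateral direction (a higher number here means that the compound crosses the layer faster, a lower number that the compound crosses the layer more slowly), so far. Compound 1 `Fc1ccccc1Cc1nc(-c2nc(C(F)(F)F)n[nH]2)c2ccccn12` gives 17 10^-6 cm/s in this assay. Compound 3 `Cc1ncc(Cc2nc(-c3nc(C(F)(F)F)n[nH]3)n3cccc(F)c23)cn1` gives 23 10^-6 cm/s in this assay. Compound 2 `Cc1n[nH]c(-c2nc(Cc3ccccc3F)c3ccccn23)n1` gives 1 10^-6 cm/s in this assay, the lowest of the three numbers; compound 1 lies nearest to it and compound 3 furthest, both gaps beyond the scatter.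

Compound 4 `Fc1ccccc1Cc1nc(-c2nc(Cc3ccccc3)n[nH]2)n2ccccc12` has not yet been measured in this assay. It differs from compound 2 in one place: phenyl in place of hydrogen on a saturated chain carbon bound to an aromatic carbon.

Within the data shown here, no step between measured compounds covers this change, so only the spread of numbers seen can guide an expectation. Compound 1 with 17 10^-6 cm/s and compound 3 with 23 10^-6 cm/s show that numbers far above that of compound 2 occur among close analogues. For compound 4 the step of a 10-fold higher number from compound 2 to compound 4 (1.00 log units; beyond the scatter) is expected to be upward and beyond the scatter. Compound 4 is therefore estimated at 10 10^-6 cm/s in this assay, with a range from 3 10^-6 cm/s to 25 10^-6 cm/s, pending the measurement.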

Compound 4, apparent permeability: 0.5 10^-6 cm/s
Compound 4: middle estimate off by 20-fold (1.30 log units), on the high side, outside the stated range (below it).
By their numbers in this assay, from the lowest: compounds 4 and 2 (each within the scatter of the next); then compounds 1 and 3 (each within the scatter of the next).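

In this assay, phenyl in place of hydrogen on a saturated chain carbon bound to an aromatic carbon gives a 2.0-fold lower number from compound 2 to compound 4 (0.30 log units; within the scatter). Among these compounds, this is the first reading at this position: the change from methyl to benzyl, with its added six-membered aromatic ring of carbon only, leaves compound 4 within the scatter of compound 2. No measurement at hand accounts for this result.

A single step cannot show whether this position is insensitive in general, and an amine, a carboxylic acid or a longer chain at the same place could still give a step beyond the scatter. On these data alone, it also remains open whether the methyl to benzyl change would give a step of similar size on the core of compound 1 or compound 3.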